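Replacing one selenium chain with an amino group

The compounds below may be only part of what the source reports. "The series", "measured", "known", "first", "only" and "open" are said of these compounds alone.

Compound 1, `CCCCC[Se]c1nc([Se]CCCCC)c2ccccc2n1`, gives > 100000 nM in an ADME assay on 184B5 cells (Homo sapiens) for cytotoxicity, read by MTT assay, with a stated time of 72 h; on this read-out lower numbers stand for stronger inhibition of growth and higher numbers for weaker inhibition of growth; this is a limit of the assay, not a number.
Compound 2, `CSc1nc(NCc2ccc([Se]C)cc2)c2ccccc2n1`, gives > 100000 nM in this assay; this too is a limit, not a number.
Compound 3, `CCCCC[Se]c1nc(N)c2cccnc2n1`, gives 40200 nM in this assay.

Compound 1 therefore stands at the limit of > 100000 nM in this assay, at which 2 of the 3 values shown sit, so its own strength of growth inhibition is not pinned down. Compound 4, `CCCCC[Se]c1nc(N)c2ccccc2n1`, has not yet been measured in this assay. It differs from compound 1 by one nitrogen atom in place of a group of 6 heavy atoms (5 carbon, 1 selenium; no ring), on an aromatic carbon. Within the data shown here, no measured pair of compounds repeats this change, so no measured step can be quoted for it. The nearest guide is compound 3, which also carries an amino group together with one selenium-bearing chain, though on a different core, and which reaches a measurable number. On that basis the step from compound 1 to compound 4 is expected to be an at least 2.2-fold lower number from compound 1 to compound 4 (0.34 log units; beyond the scatter), toward stronger inhibition of growth. Compound 4 is estimated at 45000 nM, within a range from 15000 nM to 130000 nM, with a real chance that only a limit is reported again.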

Compound 4, concentration for total growth inhibition: 43600 nM
The estimate for compound 4 lay 1.0-fold (0.01 log units) above the measured number; the range from low to high includes it.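

Exchanging one selenium chain for an amino group on this aromatic carbon gives an at least 2.2-fold lower number from compound 1 to compound 4 (0.36 log units; beyond the scatter) in this assay and turns a limit into a measurable number on the core of compound 1. As far as these compounds go, the true size of this step stays unknown because compound 1 gives a limit and not a number: the limit of > 100000 nM in this assay, at which 2 of the 4 values shown sit. Compound 4 gives 43600 nM and compound 3 gives 40200 nM in this assay as well, so these two printed values lie close together, and both compounds carry the amino group with one selenium chain.

The compounds shown leave open whether a methylamino group or a hydroxyl group on the same carbon would bring a similar step. They also leave open what a longer chain on the remaining selenium would do to the number.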